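A few compounds are considered here, and "the series" means these few. Any claim that something is new, unique, unknown or untested is made for them only; others in the source may bear on it.

Two compounds are measured in an assay on HEK293 cells for inhibition of N-acylethanolamine-hydrolyzing acid amidase (Rattus norvegicus), read by LC-MS, with a stated time of 30 min; on this read-out higher numbers stand for weaker inhibition and lower numbers for stronger inhibition. Compound 1 `Nc1ccc(CCCCCC(=O)N2CCOC2=O)cc1` gives 15700 nM; compound 2 `O=C1OCCN1C(=O)c1ccc(Oc2ccccc2)cc1` gives 680 nM, the lower of the two values, with compound 1 standing well above it. Compound 3 `O=C1OCCN1C(=O)c1ccc(OC2CCCCC2)cc1` is not yet measured. It differs from compound 2 by cyclohexyl in place of phenyl on an oxygen on an aromatic ring. Among the measured compounds shown here, no measured pair shows this change, so its size is open; nothing in the two values speaks for a move beyond the scatter in either direction, and a step within the scatter is expected, as a 1.3-fold higher number from compound 2 to compound 3 (0.12 log units; within the scatter). Compound 3 is therefore expected near 900 nM, with a range from 300 nM to 3000 nM.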

Compound 3, half-maximal inhibitory concentration: 92 nM
The estimate for compound 3 lay 9.8-fold (0.99 log units) above the measured number; the whole stated range lies above it.
By their numbers in this assay, from the lowest: compound 3; then compound 2; then compound 1.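

Cyclohexyl in place of phenyl on an oxygen on an aromatic ring gives a 7.4-fold lower number from compound 2 to compound 3 (0.87 log units; beyond the scatter) in this assay. An aromatic ring at this position is therefore not needed for inhibition, and the non-aromatic ring of the same heavy-atom count gives the stronger inhibition of this single pair. Nothing available accounts for the size of this step. Still open, as far as these compounds go, is how cyclopentyl, a straight hexyl chain or a piperidine ring on this oxygen would compare with cyclohexyl. A single pair also cannot show whether the step carries over to other cores.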